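The source may report more compounds than this note shows. Statements on the series, on what has been measured and on what is new or still open speak of the compounds shown alone.

Compound 1 `COc1ccc(-c2nc(CNc3cccc(Cl)c3)nc3ccsc23)cn1`: in an ADME assay on cells (Homo sapiens) for cytotoxicity, read by resazurin assay, with a stated time of 5 days (on this read-out higher numbers stand for lower toxicity in this test and lower numbers for higher toxicity in this test), compound 1 gives > 50000 nM, which is a limit of the assay and not a number.
Compound 2 `COc1ccc(-c2nc(C(C)(C)S(=O)(=O)c3cccc(Cl)c3)nc3ccsc23)cn1`: in this assay compound 2 gives > 50000 nM, again a limit.
Compound 3 `O=S(=O)(Cc1nc(-c2ccncc2)c2sccc2n1)c1cccc(Cl)c1`: in this assay compound 3 gives > 50000 nM, also a limit.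

Compound 1 therefore stands where every measured compound stands, at the limit of > 50000 nM in this assay, at which 3 of the 3 values shown sit. Compound 4 `COc1ccc(-c2nc(COc3cccc(Cl)c3)nc3ccsc23)cn1` differs from compound 1 in one place: 3-chlorophenoxy in place of (3-chlorophenyl)amino on a saturated chain carbon bound to an aromatic carbon. For the measured compounds named here, no pair of measured compounds that differ in one place is available, so the size of this change in this assay cannot be read from the data. Given that all three values sit at the limit of > 50000 nM in this assay, at which 3 of the 3 values shown sit, the step that the limit leaves unreadable from compound 1 to compound 4 is expected to be none beyond the scatter. Compound 4 is estimated at 60000 nM in this assay, within 30000 nM to 200000 nM, most likely reported only as a limit.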

Compound 4, half-maximal cytotoxic concentration: > 50000 nM
Compound 4: only a limit was reported; the forecaster's own chance of this, stated with the estimate: 85%; the middle value is on the limit's open side.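

No new step can be read between compound 1 and compound 4, since both results are limits of the assay: the limit of > 50000 nM in this assay, at which 4 of the 4 values shown sit.

The compounds shown leave open whether 3-chlorophenoxy and (3-chlorophenyl)amino differ at all in this assay, and at what concentration any of these compounds would become toxic.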